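The source may report more compounds than this note shows. Statements on the series, on what has been measured and on what is new or still open speak of the compounds shown alone.

Measured compounds:
compound 1, `CC/N=C(\S)NCCCCCn1nc(-c2ccccc2)ccc1=O`: 66.4%
compound 2, `C/N=C(\S)NCCn1nc(C)ccc1=O`: 6%
compound 3, `NC(=O)SCCCCCN1NC=CC=C1c1ccccc1`: 90.3%

In a functional assay on the whole organism with Rattus norvegicus as the target, at a dose of 100 mg/kg (on this read-out higher numbers stand for more inhibition at the one dose given (going by the name of the read-out) and lower numbers for less inhibition), compound 1 gives 66.4%, the second highest of the three numbers. Compound 3 gives 90.3%, a number beyond the scatter above that of compound 1, while compound 2 gives 6%, a number far below it, again beyond the scatter. Among the measured compounds shown here, no pair of measured compounds differs in a single place, so the measured set alone says nothing about any one change at one position.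

Compound 4, `C/N=C(\S)NCCCCCCn1nc(-c2ccccc2)ccc1=O`, has not yet been measured in this assay. It differs from compound 1 in this way: a group of 6 heavy atoms (3 carbon, 2 nitrogen, 1 sulfur; no ring) in place of a group of 6 heavy atoms (3 carbon, 2 nitrogen, 1 sulfur; no ring), on a saturated chain carbon, five bonds along the chain from an aromatic nitrogen. The two compounds are built of the same atoms joined differently, and what leaves and what enters are counted alike. For the measured compounds named here, with no measured step to set a direction, compound 1 stays the only anchor. The estimate for compound 4 is 62%, expected to lie between 40% and 82%. The expected step is a number 4.4 percentage points lower from compound 1 to compound 4 (within the scatter), none beyond the scatter.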

Compound 4, a percentage reported as inhibition, in the whole organism at one dose (the size of the read-out at that dose, not a potency): 22.2%
Estimate against measurement, compound 4: 39.8 percentage points above, and the stated range ends above it.
By their numbers in this assay, from the lowest: compound 2; then compound 4; then compound 1; then compound 3.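

Among the compounds shown here, this is the first pair in the set that can be read at one place, and in this assay the step is a number 44.2 percentage points lower from compound 1 to compound 4 (beyond the scatter) even though the atoms stay the same. The group that leaves and the group that enters count alike in heavy atoms, double bonds outside aromatic rings, hydrogen-bond donors and acceptors, and net charge, so at this saturated chain carbon those counts alone do not fix the read-out: how the same atoms are joined matters here. Nothing measured gives a reason for this step.

The compounds shown leave open how the read-out would respond to an amine or a carboxylic acid at this place. They also leave open whether a longer chain would take it further in the same direction.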